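Swapping the Amide Substituent on a Shared Benzimidazole-Free Core

The source may hold more compounds than are shown below. What is called first, only, known or untested is meant among the compounds shown, and "the series" means these compounds.

Measured compounds:
Compound 1 `CCCn1c(SCc2cc([N+](=O)[O-])ccc2OC)nc2cc(NC(=O)NC(C)(C)C)cc(C(=O)OC)c21`: 37 nM
Compound 2 `CCCn1c(SCc2cc([N+](=O)[O-])ccc2OC)nc2cc(NC(=O)NC(C)(C)C)cc(C(=O)NC)c21`: 41 nM
Compound 3 `CCCn1c(SCc2cc([N+](=O)[O-])ccc2OC)nc2cc(NC(=O)NC(C)(C)C)cc(C(=O)NC(C)(C)C)c21`: 410 nM

All three were tested in an assay on isolated protein for inhibition of Gonadotropin-releasing hormone receptor (Homo sapiens); a higher number here means a weaker inhibitor, a lower number a stronger inhibitor. Compound 3 gives the highest number of the three: the step of a 10-fold higher number from compound 2 to compound 3 (1.00 log units; beyond the scatter) and the step of an 11-fold higher number from compound 1 to compound 3 (1.04 log units; beyond the scatter) both go beyond the scatter, while a 1.1-fold higher number from compound 1 to compound 2 (0.04 log units; within the scatter) lies within it. Compound 4 `CCCn1c(SCc2cc([N+](=O)[O-])ccc2OC)nc2cc(NC(=O)NC(C)(C)C)cc(C(=O)NCc3ccncc3)c21` differs from compound 3 in one place: (pyridin-4-yl)methyl in place of tert-butyl on an amide-type nitrogen. The step that bears on this is a 10-fold higher number from compound 2 to compound 3 (1.00 log units; beyond the scatter), where a larger group on this nitrogen raised the number. Compound 4 carries a group that is larger still but shaped differently, so the expected step is a 3.4-fold lower number from compound 3 to compound 4 (0.53 log units; beyond the scatter), toward a lower number. Compound 4 is therefore estimated at 120 nM, within a range from 30 nM to 500 nM.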

Compound 4, half-maximal inhibitory concentration: 61 nM
The estimate for compound 4 lay 2.0-fold (0.29 log units) above the measured number; the measured number falls inside the stated range.
By their numbers in this assay, from the lowest: compounds 1, 2 and 4 (each within the scatter of the next); then compound 3.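

The change shows that the number of heavy atoms on this amide nitrogen does not alone set the result: (pyridin-4-yl)methyl has more than tert-butyl, yet replacing tert-butyl gives a 6.7-fold lower number from compound 3 to compound 4 (0.83 log units; beyond the scatter). The other two steps, a 1.5-fold higher number from compound 2 to compound 4 (0.17 log units; within the scatter) and a 1.6-fold higher number from compound 1 to compound 4 (0.22 log units; within the scatter), lie within the scatter, so this position tolerates the (pyridin-4-yl)methyl group as well as it does methylamino or methoxy. No available evidence explains this difference between the two larger groups.

A benzyl group would test whether the pyridine nitrogen matters, and a longer chain ending in pyridin-4-yl would test the length of the link.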